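The source may hold more compounds than are shown below. What is called first, only, known or untested is meant among the compounds shown, and "the series" means these compounds.

Measured so far, in an ADME assay on MT2 cells (Homo sapiens) for cytotoxicity, read by XTT assay, with a stated time of 4 days; a higher number here means that more compound is tolerated, a lower number that less compound is tolerated:
compound 1, `Cc1cc(/C=C2\SC(=S)N(Cc3cccc(C(F)(F)F)c3)C2=O)c(C)n1-c1ccc(O)c(C(=O)O)c1`, gives 26300 nM
compound 2, `Cc1cc(/C=C2\SC(=S)N(Cc3cccc(Br)c3)C2=O)c(C)n1-c1ccc(O)c(C(=O)O)c1`, gives 48200 nM
compound 3, `Cc1cc(/C=C2\SC(=S)N(Cc3ccccc3C(F)(F)F)C2=O)c(C)n1-c1ccc(O)c(C(=O)O)c1`, gives 28800 nM

Compound 4, `Cc1cc(/C=C2\SC(=S)N(Cc3ccccc3Br)C2=O)c(C)n1-c1ccc(O)c(C(=O)O)c1`, has not yet been measured in this assay.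

The change from compound 1 to compound 2 is bromo in place of trifluoromethyl on an aromatic carbon, and it made a step of a 1.8-fold higher number from compound 1 to compound 2 (0.26 log units; within the scatter). The same change leads from compound 3 to compound 4: bromo in place of trifluoromethyl on an aromatic carbon. The two cores differ in that (2-(trifluoromethyl)phenyl in place of 3-(trifluoromethyl)phenyl on a saturated chain carbon bound to an amide-type nitrogen in a ring), a change that gave a 1.1-fold higher number from compound 1 to compound 3 (0.04 log units; within the scatter). Around the place, the two cases are not identical: in the measured pair the bromo sits meta to a large group, whereas in compound 4 it sits ortho to a large group, so this is the same kind of change rather than the same change.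

From compound 3 to compound 4 a step of about a 1.4-fold higher number from compound 3 to compound 4 (0.14 log units; within the scatter) is expected, resting on the earlier step of a 1.8-fold higher number from compound 1 to compound 2 (0.26 log units; within the scatter), which lay within the scatter. Compound 4 is therefore estimated at 40000 nM, plausibly between 18000 nM and 90000 nM.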

Compound 4, half-maximal cytotoxic concentration: 25700 nM
Estimate against measurement, compound 4: 1.6-fold (0.19 log units) above, within the range that was stated.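

In this assay, bromo in place of trifluoromethyl gives a 1.1-fold lower number from compound 3 to compound 4 (0.05 log units; within the scatter), and the same change on the two cores cannot be told apart: the same change on two cores in this assay, a 1.8-fold higher number (0.26 log units; within the scatter) from compound 1 to compound 2 and a 1.1-fold lower number (0.05 log units; within the scatter) from compound 3 to compound 4, 2.1-fold (0.31 log units) apart, within the scatter of two such steps. The other new steps are also small, with a 1.9-fold lower number from compound 2 to compound 4 (0.27 log units; within the scatter) and a 1.0-fold lower number from compound 1 to compound 4 (0.01 log units; within the scatter), so all four compounds lie within the scatter of one another. For the compounds shown here, this fits the change carrying over from one core to the other, but it does not show that the two steps are truly equal: a real difference smaller than the scatter would go unseen, and only two cores are compared.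

Still open, from the compounds shown here alone, is whether another group on the aromatic ring, such as an amine or a nitrile, would give a step beyond the scatter. The same question stands for a longer chain in place of the benzyl link.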